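A few compounds are considered here, and "the series" means these few. Any claim that something is new, unique, unknown or untested is made for them only; others in the source may bear on it.

Measured compounds:
Compound 1 `ClCc1ccc(Cn2cnc3c(Cl)ncnc32)cc1` — in a functional assay on PC-3 cells (Homo sapiens) for cytotoxicity, read by sulforhodamine B assay, with a stated time of 48 h (on this read-out lower numbers stand for higher toxicity in this test and higher numbers for lower toxicity in this test), compound 1 gives > 100000 nM, a limit of the assay rather than a number.
Compound 2 `ClCc1ccccc1Cn1cnc2nc(Cl)nc(Cl)c21` — in this assay compound 2 gives "not determined" (no result reported).

The account follows the step from compound 2 to compound 3 `ClCc1ccccc1Cn1cnc2ncnc(Cl)c21`. Compound 2 stands without a single number in this assay; of the two values shown, one is a limit and none is a measured figure. Going by the values given here, the only measured entry is the one for compound 1, which sits at the limit of > 100000 nM in this assay, at which 1 of the 2 values shown sits.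

Compound 3 differs from compound 2 in one place: hydrogen in place of chloro on an aromatic carbon.

Among the compounds with values here, no step between measured compounds is available, so the size of the step from compound 2 to compound 3 in this assay cannot be read from the data. The expectation here is for no change beyond the usual scatter, with compound 3 lying, like compound 1, at or near the limit of this assay.

For compound 3 the estimate in this assay is 100000 nM, expected to fall between 30000 nM and 300000 nM.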

Compound 3, concentration lethal to 50% of the cells: 74100 nM
Compound 3: the middle estimate sits 1.3-fold (0.13 log units) above what was measured, and the stated range covers the measured number.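

In this assay, going by these compounds alone, compound 2 has no number and compound 3 gives 74100 nM; no step from compound 2 to compound 3 can be read from these two entries. The compounds shown leave open what putting hydrogen in place of the chloro group on the aromatic carbon does in this assay.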